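Swapping the Quinoline Amide for a Cinnamamide: Expected Potency

This account rests on a few compounds, and the source may have more. Where it says the series, first, only, none or still open, it means among the compounds named here.

Compound 1, `CN1[C@@H]2c3[nH]c4ccccc4c3C[C@H]1[C@H](C#N)N1[C@@H](CN3C(=O)c4ccccc4C3=O)c3[nH]c4ccccc4c3C[C@@H]21`: 40 nM in a functional assay on HCT-116 cells (Homo sapiens) for cytotoxicity, read by MTT assay, with a stated time of 72 h; a lower number here means a stronger inhibitor, a higher number a weaker inhibitor
Compound 2, `CCc1ccc(C(=O)NC[C@H]2c3[nH]c4ccccc4c3C[C@H]3[C@H]4c5[nH]c6ccccc6c5C[C@@H]([C@H](C#N)N23)N4C)cc1`: 100 nM
Compound 3, `CN1[C@@H]2c3[nH]c4ccccc4c3C[C@H]1[C@H](C#N)N1[C@@H](CNC(=O)c3ccc4ccccc4n3)c3[nH]c4ccccc4c3C[C@@H]21`: 240 nM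

Compound 3 gives the highest number of the three in this assay, so it is the weakest inhibitor among them. The nearest step is a 2.4-fold higher number from compound 2 to compound 3 (0.38 log units; beyond the scatter), and compound 1, at 40 nM, stands further below still.

Compound 4, `CN1[C@@H]2c3[nH]c4ccccc4c3C[C@H]1[C@H](C#N)N1[C@@H](CNC(=O)/C=C/c3ccccc3)c3[nH]c4ccccc4c3C[C@@H]21`, differs from compound 3 in one place: 2-phenylethenyl in place of quinolin-2-yl on a carbonyl carbon. Of the two measured steps, the one that bears most directly on this change is a 2.4-fold higher number from compound 2 to compound 3 (0.38 log units; beyond the scatter), since there too only the group on the carbonyl carbon of the amide was exchanged, and moving from a simple benzene-based group to quinolin-2-yl cost a modest amount of potency. The step of a 2.5-fold higher number from compound 1 to compound 2 (0.40 log units; beyond the scatter) concerns a different part of the shared core and says little here. Going back from quinolin-2-yl to a group built on a single benzene ring, joined to the carbonyl through a double bond, is therefore expected to recover part of that loss, giving a modest step of a 1.6-fold lower number from compound 3 to compound 4 (0.20 log units; within the scatter).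

Compound 4 is thus estimated at 150 nM in this assay, with a range from 60 nM to 400 nM.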

Compound 4, half-maximal inhibitory concentration: 1960 nM
Compound 4: middle estimate off by 13-fold (1.12 log units), on the low side; measured number above the stated range.
By their numbers in this assay, from the lowest: compound 1; then compound 2; then compound 3; then compound 4.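

In this assay, among these compounds, the group on the carbonyl carbon can matter more than the earlier steps suggested, as an 8.2-fold higher number from compound 3 to compound 4 (0.91 log units; beyond the scatter) shows that replacing quinolin-2-yl, with its two rings, by 2-phenylethenyl, with one, makes the compound weaker rather than stronger. Having a single benzene ring is also not enough to keep potency: 4-ethylphenyl and 2-phenylethenyl both have one, yet a 20-fold higher number from compound 2 to compound 4 (1.29 log units; beyond the scatter) is the result of exchanging them, so the way that ring is attached or substituted counts as well. Among the compounds shown here, compound 4 is now the weakest of the four, and a 49-fold higher number from compound 1 to compound 4 (1.69 log units; beyond the scatter) marks the full spread of the series so far, with every step to compound 4 beyond the usual scatter.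

Nothing available here explains why 2-phenylethenyl performs so poorly. On these data alone, it remains open whether 2-phenylethyl, the same group with its double bond saturated, would sit nearer to compound 2 or to compound 4, and how an unsubstituted phenyl or a ring carrying a carboxylic acid would behave on the same carbonyl carbon.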